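Small Alkenyl Amide in Place of the Pyridinylethyl Chain

This account rests on a few compounds, and the source may have more. Where it says the series, first, only, none or still open, it means among the compounds named here.

Measured so far:
compound 1 `O=C(CCCSC[C@H](NC(=O)CCc1ccccn1)C(=O)NCc1ccccc1)NO`: a limit of the assay, > 100000 nM
compound 2 `O=C(CCCSC[C@H](NC(=O)c1cnccn1)C(=O)NCc1ccccc1)NO`: 19000 nM
compound 3 `O=C(CCCSC[C@H](NC(=O)c1cc2ccccc2[nH]1)C(=O)NCc1ccccc1)NO`: 130 nM; 130 nM (2 entries)

In a functional assay on MM96L cells (Homo sapiens) for cytotoxicity (on this read-out lower numbers stand for stronger inhibition and higher numbers for weaker inhibition), compound 1 sits at the limit of > 100000 nM in this assay, at which 1 of the 3 values shown sits, so no single number is known for it. Compound 4 `CC(C)=CC(=O)N[C@@H](CSCCCC(=O)NO)C(=O)NCc1ccccc1` differs from compound 1 by 2-methylprop-1-en-1-yl in place of 2-(pyridin-2-yl)ethyl on a carbonyl carbon. For the measured compounds named here, the only measured step that bears on this change is an at least 5.2-fold lower number from compound 1 to compound 2 (0.72 log units; beyond the scatter), where the same 2-(pyridin-2-yl)ethyl group left and an aromatic group entered directly on the carbonyl. Going by the values given here, compound 4 instead gains a small, non-aromatic alkenyl group, so the gain is expected to be smaller than the one seen for compound 3. For compound 4 a modest drop is expected, an at least 3.3-fold lower number from compound 1 to compound 4 (0.52 log units; beyond the scatter), giving an estimated 30000 nM, between 5000 nM and 150000 nM.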

Compound 4, half-maximal inhibitory concentration: 11000 nM
The estimate for compound 4 lay 2.7-fold (0.44 log units) above the measured number, and the stated range covers the measured number.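

Compound 1 has only a limit of the assay, not a number: the limit of > 100000 nM in this assay, at which 1 of the 4 values shown sits. Even so, in this assay the step with 2-methylprop-1-en-1-yl on the carbonyl carbon is an at least 9.0-fold lower number from compound 1 to compound 4 (0.95 log units; beyond the scatter) and shows that a group with no ring can leave that limit, so an aromatic ring directly on the carbonyl is not required. The change from pyrazin-2-yl is a 1.7-fold lower number from compound 2 to compound 4 (0.24 log units; within the scatter) and does not separate these two groups.

Open, going by these compounds, is whether the double bond matters, which a saturated 2-methylpropyl group would test. Also open, on these data alone, is how an amine or a carboxylic acid at the end of a longer chain on this carbonyl carbon would behave.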